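A few compounds are considered here, and "the series" means these few. Any claim that something is new, unique, unknown or untested is made for them only; others in the source may bear on it.

Working notes on the series. For the measured compounds named here, compound 1 `O=C(Cc1cccnc1)c1cc2cc(F)ccc2[nH]1` carries the lowest number so far in an assay on isolated protein for inhibition of Indoleamine 2,3-dioxygenase 1 (Homo sapiens), read by spectrophotometry (a lower number here means a stronger inhibitor, a higher number a weaker inhibitor), at 36000 nM. Compound 2 `O=C(Cc1ccccn1)c1cc2ccccc2[nH]1` gives 37000 nM in this assay, a number within the scatter of compound 1, so no order between those two is claimed. Compound 3 `O=C(Nc1cccnc1)c1cc2ccccc2[nH]1` gives 94000 nM in this assay, a gap to compound 1 that lies beyond the scatter. Going by the values given here, no two measured compounds differ in a single place, so no measured step guides the next change. Compound 4 `O=C(Cc1cccnc1)c1cc2cc(OC(F)(F)F)ccc2[nH]1` differs from compound 1 thus: trifluoromethoxy in place of fluoro on an aromatic carbon. Among the compounds with values here, with no matched step among the measured compounds, only a small step is expected, in either direction or none beyond the scatter: the estimated step is a 1.4-fold lower number from compound 1 to compound 4 (0.16 log units; within the scatter). Compound 4 is expected to give 25000 nM in this assay, within a range from 8000 nM to 80000 nM.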

Compound 4, half-maximal inhibitory concentration: 13100 nM
Beside the measured number, compound 4's estimate is 1.9-fold (0.28 log units) above it; the range from low to high includes it.
By their numbers in this assay, from the lowest: compound 4; then compounds 1 and 2 (each within the scatter of the next); then compound 3.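

For the compounds shown here, this is the first measured single-place step: on this aromatic carbon, trifluoromethoxy in place of fluoro gives a 2.7-fold lower number from compound 1 to compound 4 (0.44 log units; beyond the scatter) in this assay, a step beyond the scatter. The position therefore responds to a change of group, and the five heavy atoms of trifluoromethoxy are accepted where fluoro has one. Nothing measured explains this step.

Open, on these data alone, is whether a methoxy, a chloro or an amine on the same carbon would give a similar number. Also open, as far as these compounds go, is whether the same change would carry over to the cores of compound 2 and compound 3.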